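A few compounds are considered here, and "the series" means these few. Any claim that something is new, unique, unknown or untested is made for them only; others in the source may bear on it.

Compound 1 `Cc1ccc(C)c(N2C(=O)/C(=C/c3ccc(F)cc3)S/C2=N\NC(=O)c2cc3ccccc3oc2=O)c1` was tested in an assay on isolated protein for inhibition of Alpha glucosidase (Homo sapiens), with stated times of 5 min and 30 min; on this read-out higher numbers stand for weaker inhibition and lower numbers for stronger inhibition. In this assay compound 1 gives only a limit, > 100000 nM, not a number. Of the three values shown, compound 1 alone sits at the top (the limit of > 100000 nM in this assay, at which 1 of the 3 values shown sits). The other two measured compounds, which share no close structural link with it, give numbers: compound 2 `Cc1ccccc1C(=O)/N=c1\scc(C)n1-c1cc(Cl)c(Cl)cc1Cl` gives 150 nM, and compound 3 `Cc1cs/c(=N\C(=O)c2cccc3ccccc23)n1-c1cc(Cl)c(Cl)cc1Cl` gives 150 nM. Compound 4 `Cc1cccc(N2C(=O)/C(=C/c3ccc(F)cc3)S/C2=N\NC(=O)c2cc3ccccc3oc2=O)c1C` is made of the same atoms as compound 1, joined differently: 2,3-dimethylphenyl in place of 2,5-dimethylphenyl on an amide-type nitrogen in a ring. For the measured compounds named here, no pair of measured compounds differs in a single place, so there is no measured step to lean on. Exchanging 2,5-dimethylphenyl for 2,3-dimethylphenyl is expected to move the step that the limit leaves unreadable from compound 1 to compound 4 by no more than the usual scatter. Compound 4 is therefore estimated at 150000 nM, in a range from 50000 nM to 500000 nM, most likely reported again only as a limit.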

Compound 4, half-maximal inhibitory concentration: > 100000 nM
Compound 4: only a limit was reported; the forecaster's own chance of this, stated with the estimate: 80%; the middle value does not contradict the limit.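

For the compounds shown here, compound 1 and compound 4 each give only a limit, so no step between them can be read, because both values sit at the assay's ceiling: the limit of > 100000 nM in this assay, at which 2 of the 4 values shown sit. The compounds shown leave open how strongly either one inhibits, and whether 2,3-dimethylphenyl in place of 2,5-dimethylphenyl changes that at all.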